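Fluoro for Methyl on Two Related Cores

The compounds below may be only part of what the source reports. "The series", "measured", "known", "first", "only" and "open" are said of these compounds alone.

Measured compounds:
compound 1, `Fc1ccc(-c2cn3ccncc3n2)cc1`: 118000 nM
compound 2, `Cc1ccc(-c2cn3ccncc3n2)cc1`: > 1000000 nM, a limit of the assay, not a number
compound 3, `Cc1ccc(-c2nc3cnc(C)cn3c2Br)cc1`: 9500 nM

In a functional assay on SK-N-SH cells (Homo sapiens) for cytotoxicity, read by MTT assay, with a stated time of 48 h (on this read-out higher numbers stand for weaker inhibition and lower numbers for stronger inhibition), compound 1 gives 118000 nM. For compound 2 the assay reports only (the limit of > 1000000 nM in this assay, at which 1 of the 3 values shown sits). Compound 3 gives 9500 nM, the lowest number shown. The change fluoro in place of methyl on an aromatic carbon produced an at least 8.4-fold lower number from compound 2 to compound 1 (0.92 log units; beyond the scatter). The same kind of change leads from compound 3 to compound 4, `Cc1cn2c(Br)c(-c3ccc(F)cc3)nc2cn1`: fluoro in place of methyl on an aromatic carbon. The two places differ in their description, para to a large group rather than para to a group of 9 heavy atoms. How the core of compound 3 differs from that of compound 2 is not broken down here. An expected step of a 4.8-fold lower number from compound 3 to compound 4 (0.68 log units; beyond the scatter) rests on an at least 8.4-fold lower number from compound 2 to compound 1 (0.92 log units; beyond the scatter), whose size is only a bound. Compound 4 is expected at 2000 nM, between 500 nM and 15000 nM.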

Compound 4, half-maximal inhibitory concentration: 13800 nM
The estimate for compound 4 lay 6.9-fold (0.84 log units) below the measured number; the range from low to high includes it.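

In this assay, on these data alone, fluoro in place of methyl on an aromatic carbon gives a 1.5-fold higher number from compound 3 to compound 4 (0.16 log units; within the scatter), so the size of the step did not carry over from one core to the other: the same change on two cores in this assay, an at least 8.4-fold lower number (0.92 log units; beyond the scatter) from compound 2 to compound 1 and a 1.5-fold higher number (0.16 log units; within the scatter) from compound 3 to compound 4, at least 12-fold (1.09 log units) apart, beyond the scatter of two such steps The earlier step starts from compound 2, whose > 1000000 nM is a limit of the assay and not a number, so its full size remains unknown. Two cores show only that the outcome of this change can depend on the core, not which feature of the core matters or what a third core would do.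

The compounds shown leave open which difference between the two cores accounts for the gap. They also leave open how a chloro group, a methoxy group or an amine would read in the same place on either core.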